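Adding a second methyl to the indole-bearing diterpenoid

The source may hold more compounds than are shown below. What is called first, only, known or untested is meant among the compounds shown, and "the series" means these compounds.

Of the compounds shown here, two of one shared core have been measured in a functional assay on SW1573 cells (Homo sapiens) for inhibition, read by sulforhodamine B assay, with a stated time of 48 h; on this read-out higher numbers stand for weaker inhibition of growth and lower numbers for stronger inhibition of growth. Compound 1 `COC(=O)[C@@]1(C)CCC=C2[C@@H]1CC[C@@H](C)[C@]2(C)Cc1c[nH]c2c(C)cccc12` gives 7800 nM in this assay. Compound 2 `COC(=O)[C@@]1(C)CCC=C2[C@@H]1CC[C@@H](C)[C@]2(C)Cc1c(C)[nH]c2ccccc12` gives 14000 nM in this assay, and the gap between the two values lies within the scatter of repeated measurements, so the two compounds cannot be told apart on these numbers. Compound 3 `COC(=O)[C@@]1(C)CCC=C2[C@@H]1CC[C@@H](C)[C@]2(C)Cc1c(C)[nH]c2c(C)cccc12` has not yet been measured in this assay. It differs from compound 2 in one place: methyl in place of hydrogen on an aromatic carbon. Among the measured compounds shown here, no step between measured compounds informs this change, and the one comparison available, between compound 1 and compound 2, shows no difference beyond the scatter. The step from compound 2 to compound 3 is therefore expected to be small, a 1.2-fold lower number from compound 2 to compound 3 (0.07 log units; within the scatter), with no direction beyond the scatter. For compound 3 a value of 12000 nM is estimated in this assay, within a range from 4000 nM to 36000 nM.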

Compound 3, concentration for 50% growth inhibition: 15000 nM
Compound 3: middle estimate off by 1.3-fold (0.10 log units), on the low side; the measured number falls inside the stated range.
By their numbers in this assay, from the lowest: compounds 1, 2 and 3 (each within the scatter of the next).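

In this assay, placing a methyl on the aromatic carbon of the six-membered ring, ortho to a fused ring and meta to a fused ring, gives a 1.1-fold higher number from compound 2 to compound 3 (0.03 log units; within the scatter). The other single-place comparison, also methyl in place of hydrogen on an aromatic carbon, gives a 1.9-fold higher number from compound 1 to compound 3 (0.28 log units; within the scatter), so with both methyls present on the shared core, neither replacement separates compound 3 from its single-methyl partner. No supporting information bears on why these steps stay so small.

The compounds shown leave open whether this aromatic carbon responds only weakly to any substituent or just to methyl. An amine, a carboxylic acid or a longer chain such as propyl at the same carbon could still give a step beyond the scatter.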